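Three limits and an untested methoxyphenyl analogue

The compounds below may be only part of what the source reports. "The series", "measured", "known", "first", "only" and "open" are said of these compounds alone.

Compound 1 `O=C1Nc2ccc(F)cc2C1CCCCN1CCN(c2ccc(F)cc2)CC1`, compound 2 `CCC1(CCCCN2CCN(c3ccc(F)c(Cl)c3)CC2)C(=O)Nc2ccccc21` and compound 3 `CCC1(CCCCN2CCN(c3ccc(Cl)cc3)CC2)C(=O)Nc2cc(F)ccc21` were examined in a functional assay on the whole organism (strain Wistar) with Rattus norvegicus as the target, with a stated time of 5 min; on this read-out lower numbers stand for an effect already at smaller amounts and higher numbers for an effect only at larger amounts of compound. For compound 1 the result is a limit of the assay, > 10 mg/kg. For compound 2 the result is likewise a limit and not a number, > 20 mg/kg. For compound 3 the result is also a limit, > 20 mg/kg. Compound 2 thus stands at the limit of > 20 mg/kg in this assay, at which 2 of the 3 values shown sit. One further value stands at the limit of > 10 mg/kg in this assay, at which 1 of the 3 values shown sits. For the measured compounds named here, no step between measured compounds can be sized, as none of the three gives a number in this assay.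

Compound 4 `CCC1(CCCCN2CCN(c3ccccc3OC)CC2)C(=O)Nc2ccccc21` has not yet been measured in this assay. It differs from compound 2 by 2-methoxyphenyl in place of 3-chloro-4-fluorophenyl on an amine nitrogen in a ring. With compound 2 at a limit, the size of the step cannot be read from the data; a shift beyond the scatter, toward an effect at smaller amounts, would be needed for compound 4 to give a number at all. The expected step is an at least 1.3-fold lower number from compound 2 to compound 4 (0.12 log units; that floor lies within the scatter), with a real chance that only a limit is reported again. Compound 4 is expected to give about 15 mg/kg in this assay, estimated to lie between 4 mg/kg and 40 mg/kg.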

Compound 4, minimum effective dose: 10 mg/kg
Estimate against measurement, compound 4: 1.5-fold (0.18 log units) above, within the range that was stated.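

In this assay, 2-methoxyphenyl in place of 3-chloro-4-fluorophenyl on the amine nitrogen in a ring comes with an at least 2.0-fold lower number from compound 2 to compound 4 (0.30 log units; that floor lies within the scatter). Compound 2 gives only a limit, so this step is a floor: the true step may be larger, but the part that can be read does not go beyond the usual scatter. What is new is that, with the rest of compound 2 unchanged, a group at this position gives a number at all, and compound 4 is the only one of the four compounds to do so, while compound 2 and compound 3 share one limit: the limit of > 20 mg/kg in this assay, at which 2 of the 4 values shown sit.

The compounds shown leave open whether the change follows from the methoxy group itself or from the loss of the chlorine and fluorine, a question that a plain phenyl group or a 2-ethoxyphenyl group on the same nitrogen could help to settle. They also leave open how large the step truly is, and no other step between the compounds shown can be read.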